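Fluorine on a Pendant Phenyl Across Two Cores

This account rests on a few compounds, and the source may have more. Where it says the series, first, only, none or still open, it means among the compounds named here.

Compound 1 `COc1ccc(-c2cc(C(C)=O)c3[nH]c(-c4ccccc4)cc3c2)cc1` and compound 2 `COc1ccc(-c2cc(C(C)=O)c3[nH]c(-c4ccc(F)cc4)cc3c2)cc1` share one core, while compound 3 `COc1ccc(-c2cc3cc(-c4ccccc4)cc(C(C)=O)c3[nH]2)cc1` and compound 4 `COc1ccc(-c2cc3cc(-c4ccc(F)cc4)cc(C(C)=O)c3[nH]2)cc1` share another; the difference between the two cores is not broken down here. In a functional assay on HeLa cells (Homo sapiens) for cytotoxicity, read by MTT assay, with a stated time of 2 days, tested at 10 uM (on this read-out higher numbers stand for a weaker effect at the one concentration tested and lower numbers for a stronger effect), compound 1 gives 33.9%, and compound 2 gives 46.5%. The change between them is fluoro in place of hydrogen on an aromatic carbon, and it made a step of a number 12.6 percentage points higher from compound 1 to compound 2 (beyond the scatter). In this assay compound 3 gives 51.6%. Set against compound 2, the value of compound 3 lies within the scatter, so no order between those two can be read; set against compound 1, compound 3 reads higher by an amount beyond the scatter.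

Compound 4 has not yet been measured. It differs from compound 3 by fluoro in place of hydrogen on an aromatic carbon, which is the same change, at the same place, as that from compound 1 to compound 2. A step of like size on the second core is expected, so compound 4 is expected to move by a number 9.4 percentage points higher from compound 3 to compound 4 (within the scatter) in this assay because compound 3 gives 51.6% and because the earlier step was a number 12.6 percentage points higher from compound 1 to compound 2 (beyond the scatter). Since this rests on a single earlier instance, itself of modest size, the estimate for compound 4 is 61%, expected to fall between 46% and 76%.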

Compound 4, a percentage reported as activity, at one concentration (the size of the read-out at that concentration, not a potency): 52%
Beside the measured number, compound 4's estimate is 9 percentage points above it; the measured number falls inside the stated range.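

In this assay, fluoro in place of hydrogen on the second core gave a step of a number 0.4 percentage points higher from compound 3 to compound 4 (within the scatter), whereas the same phenyl to 4-fluorophenyl change on the first core had given a step beyond the scatter. Taken one at a time, the two steps read differently, but set side by side they cannot be told apart: the same change on two cores in this assay, a number 12.6 percentage points higher (beyond the scatter) from compound 1 to compound 2 and a number 0.4 percentage points higher (within the scatter) from compound 3 to compound 4, 12.2 percentage points apart, within the scatter of two such steps This pair of cores therefore does not show that the change carries over at full size, nor does it show that the core alters the step, and with a single step on each core, a real dependence on the core remains neither established nor excluded.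

The compounds shown hold only hydrogen or fluoro at this place, on the six-membered aromatic ring and para to a large group, so it remains open how a chloro, a trifluoromethyl or an amine there would read on either core, and whether such a group would behave alike on both. Every value also comes from one concentration in one cell line, which leaves open whether the two steps would look the same at other concentrations or in other cells.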